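Removing the ester from the trifluoromethyl analogue

The compounds below may be only part of what the source reports. "The series", "measured", "known", "first", "only" and "open" are said of these compounds alone.

Two measured compounds share one core, and another compound remains to be tested. Compound 1 `CCOC(=O)C1=C(C)NC2=C(C1c1ccc(F)c(Br)c1)S(=O)(=O)CC2` carries a methyl group on a double-bonded ring carbon; in a functional assay on cell membranes (Cavia porcellus) with sulfonylurea receptors; K-ATP channels (Homo sapiens) as the target, using a membrane potential dye (on this read-out lower numbers stand for an effect already at smaller amounts and higher numbers for an effect only at larger amounts of compound), compound 1 gives 501 nM. Compound 2 `CCOC(=O)C1=C(C(F)(F)F)NC2=C(C1c1ccc(F)c(Br)c1)S(=O)(=O)CC2` carries a trifluoromethyl group in that place. For compound 2 in this assay the read-out is a limit of the assay and not a number, < 10000 nM. The step that the limit leaves unreadable from compound 1 to compound 2 therefore cannot be sized, as the limit of < 10000 nM in this assay, at which 1 of the 2 values shown sits, states. Compound 3 `O=S1(=O)CCC2=C1C(c1ccc(F)c(Br)c1)C=C(C(F)(F)F)N2` differs from compound 2 by hydrogen in place of ethoxycarbonyl on a double-bonded ring carbon. Within the data shown here, no measured step touches this change, and the one measured step is itself unreadable, so no size or direction can be drawn for compound 3 in this assay from the two values shown. On this thin ground compound 3 is expected to land near compound 2, and the estimated step that the limit leaves unreadable from compound 2 to compound 3 is set close to none, with wide uncertainty. Compound 3 is estimated at 5000 nM, within 500 nM to 30000 nM.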

Compound 3, half-maximal effective concentration: 447 nM
Compound 3: the middle estimate sits 11-fold (1.05 log units) above what was measured; measured number outside the range, below it.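

No new step can be read between compound 2 and compound 3, because the read-out of compound 2 is a limit of the assay and not a number: the limit of < 10000 nM in this assay, at which 1 of the 3 values shown sits. The compounds shown leave open both the size and the direction of the exchange of ethoxycarbonyl for hydrogen in this assay.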